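This account rests on a few compounds, and the source may have more. Where it says the series, first, only, none or still open, it means among the compounds named here.

In an ADME assay on L02 cells (Homo sapiens) for antiproliferative activity, read by MTT assay, with a stated time of 48 h (on this read-out higher numbers stand for weaker inhibition and lower numbers for stronger inhibition), compound 1 (`CCn1c(C(=O)NCCN(C)C)ccc1C(CC)(CC)c1ccc(OCCC(O)(CC)CC)c(C)c1`) gives 990 nM and compound 3 (`CCOC(=O)CN(C)C(=O)c1ccc(C(CC)(CC)c2ccc(OCCC(O)(CC)CC)c(C)c2)n1CC`) gives 1990 nM, so these two sit within the scatter of each other. Compound 2 (`C#CCCOC(=O)c1ccc(C(CC)(CC)c2ccc(OCCC(O)(CC)CC)c(C)c2)n1CC`) reaches only a limit of the assay, > 50000 nM.

Compound 4 (`CCn1c(C(=O)N(C)CC(=O)O)ccc1C(CC)(CC)c1ccc(OCCC(O)(CC)CC)c(C)c1`) differs from compound 3 at a single place: hydrogen in place of ethyl on an oxygen next to a carbonyl group. The ethoxycarbonyl thus becomes carboxy, and the (ethoxycarbonyl)methyl becomes carboxymethyl.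

For the measured compounds named here, no measured step makes this exact change. The closest evidence comes from swaps of the whole group on the same carbonyl carbon, and those steps vary widely. There is a 2.0-fold higher number from compound 1 to compound 3 (0.30 log units; within the scatter), but also an at least 50-fold higher number from compound 1 to compound 2 (1.70 log units; beyond the scatter) and an at least 25-fold lower number from compound 2 to compound 3 (1.40 log units; beyond the scatter). This end of the molecule can therefore matter a great deal in this assay, or hardly at all. A moderate rise is expected, with a broad range that allows for little change or a much larger one. The expected size is a 3.5-fold higher number from compound 3 to compound 4 (0.55 log units; beyond the scatter). For compound 4 the estimate is 7000 nM, with an expected range from 1500 nM to 40000 nM.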

Compound 4, half-maximal inhibitory concentration: 2150 nM
Compound 4: the middle estimate sits 3.3-fold (0.51 log units) above what was measured; the range from low to high includes it.
By their numbers in this assay, from the lowest: compounds 1, 3 and 4 (each within the scatter of the next, the first and the last beyond it). At a limit, above all of these: compound 2.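

In this assay, replacing the ethyl with hydrogen turns the ethoxycarbonyl into a carboxy and changes the reading by no more than the scatter (a 1.1-fold higher number from compound 3 to compound 4 (0.03 log units; within the scatter)), so the ethyl ester and the free carboxy read alike at this place. Compound 4 does show a modest gap from the (2-(dimethylamino)ethyl)amino amide (a 2.2-fold higher number from compound 1 to compound 4 (0.34 log units; beyond the scatter)), whereas the step from compound 1 to compound 3 stays within the scatter. The carboxymethyl amide also stands far from the (but-3-yn-1-yl)oxy ester (an at least 23-fold lower number from compound 2 to compound 4 (1.36 log units; beyond the scatter)), though that step starts from a limit of the assay, not a number: the limit of > 50000 nM in this assay, at which 1 of the 4 values shown sits.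

On these data alone, it remains open whether a longer chain between the amide nitrogen and the carboxy, or a primary amide in place of the carboxy, would read the same. As far as these compounds go, it is also open whether a plain ethoxy on the same carbonyl carbon would match compound 2 or compound 4.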